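A few compounds are considered here, and "the series" means these few. Any claim that something is new, unique, unknown or untested is made for them only; others in the source may bear on it.

Measured compounds in a functional assay on HCT-116 cells (Homo sapiens) for inhibition, read by MTT assay, with a stated time of 48 h; on this read-out lower numbers stand for stronger inhibition and higher numbers for weaker inhibition:
compound 1, `COc1cc(NCc2ccccc2)cc(OC)c1OC`: > 80000 nM
compound 2, `CCCCC(=O)N(Cc1ccc(OC)c(O)c1)c1cc(OC)c(OC)c(OC)c1`: 170 nM

Among the measured compounds shown here, of these two values only one is a number: compound 2 holds it. The value of compound 1 is a limit, and it sits at the limit of > 80000 nM in this assay, at which 1 of the 2 values shown sits. For the measured compounds named here, compound 2 is therefore the only measured point against which anything can be set, and the spread between these two compounds, which differ in many places at once, gives no single-change step to lean on.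

Compound 3, `COc1ccc(CN(C(=O)C(C)C)c2cc(OC)c(OC)c(OC)c2)cc1O`, differs from compound 2 in one place: isopropyl in place of butyl on a carbonyl carbon. The change is small, isopropyl in place of butyl on a carbonyl carbon, with no ring, no hydrogen-bond donor or acceptor, and no net charge entering or leaving. No step between measured compounds is shown, so the size of this move in this assay can only be expected, not read off. The expectation is a step that stays within the usual scatter, with no clear direction either way.

Compound 3 is accordingly estimated at 220 nM, with a range from 60 nM to 800 nM. The step that this estimate implies, a 1.3-fold higher number from compound 2 to compound 3 (0.11 log units; within the scatter), is expected to be no larger than the scatter of repeated measurements.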

Compound 3, half-maximal inhibitory concentration: 310 nM
Beside the measured number, compound 3's estimate is 1.4-fold (0.15 log units) below it, within the range that was stated.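

In this assay, among the compounds shown here, isopropyl in place of butyl on a carbonyl carbon gives a 1.8-fold higher number from compound 2 to compound 3 (0.26 log units; within the scatter), the first step in this set that comes from a single change. At this place, where the carbonyl carbon's other neighbour is the amide-type nitrogen, the exchange of these two chains therefore produces no difference that can be told apart from the scatter of repeated measurements, so the two compounds cannot be ranked against each other in this assay. Nothing available gives a measured property that would bear on this step.

The compounds shown leave open how this place responds to a group of another kind, such as an amine, a phenyl ring or a much longer chain on the carbonyl carbon, as only two small carbon chains are compared there. Compound 1, whose > 80000 nM is a limit and not a number, differs from the other compounds in several places at once, and which of those places accounts for any difference in this assay also remains open.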